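Series notes: the group on the chain carbon at the aromatic nitrogen

This account rests on a few compounds, and the source may have more. Where it says the series, first, only, none or still open, it means among the compounds named here.

Compound 1 `CC(C)=CCn1c(CN2CCN(C(=O)C3CC3)CC2)nc2ccccc21` gives 74.3% in an assay on isolated protein for inhibition of aldehyde dehydrogenase 1A1 (Homo sapiens), read by spectrophotometry, tested at 10 uM; on this read-out lower numbers stand for less inhibition and higher numbers for more inhibition at the one concentration tested (going by the name of the read-out).
Compound 2 `O=C(C1CC1)N1CCN(Cc2nc3ccccc3n2Cc2ccc(Cl)cc2)CC1` gives 56.6%.
Compound 3 `O=C(C1CC1)N1CCN(Cc2nc3ccccc3n2CC2CCCC2)CC1` gives 44.5%.

Compound 3 stands lowest of the three measured, both steps to it lying beyond the scatter: a number 12.1 percentage points lower from compound 2 to compound 3 (beyond the scatter) and a number 29.8 percentage points lower from compound 1 to compound 3 (beyond the scatter). Compound 4 `Cc1ccccc1Cn1c(CN2CCN(C(=O)C3CC3)CC2)nc2ccccc21` differs from compound 3 by 2-methylphenyl in place of cyclopentyl on a saturated chain carbon bound to an aromatic nitrogen. Going by the values given here, the one step that bears directly on this change is a number 12.1 percentage points lower from compound 2 to compound 3 (beyond the scatter), where a six-membered aromatic ring of carbon only was replaced by the cyclopentyl; read in reverse it points to a modest gain for an aromatic ring re-entering at this place. A modest increase is therefore expected, a number 10.5 percentage points higher from compound 3 to compound 4 (beyond the scatter). For compound 4 the estimate is 55%, with an expected range from 36% to 74%.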

Compound 4, a percentage reported as inhibition, at one concentration (the size of the read-out at that concentration, not a potency): 29.1%
Estimate against measurement, compound 4: 25.9 percentage points above; the whole stated range lies above it.
By their numbers in this assay, from the lowest: compound 4; then compound 3; then compound 2; then compound 1.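

In this assay an aromatic ring at this place does not by itself raise the number: 2-methylphenyl gives a number 15.4 percentage points lower from compound 3 to compound 4 (beyond the scatter) and, against the other aromatic group, a number 27.5 percentage points lower from compound 2 to compound 4 (beyond the scatter). The step from the 2-methylprop-1-en-1-yl group is the largest in the series, a number 45.2 percentage points lower from compound 1 to compound 4 (beyond the scatter), leaving compound 4 lowest of the four. Nothing available accounts for these drops.

On these data alone, how a plain phenyl or a longer chain ending in an amine would read at this place remains open. So does whether the methyl or the ring accounts for the fall.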